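Dimethylamino step repeated on the free-amine chalcone

This account rests on a few compounds, and the source may have more. Where it says the series, first, only, none or still open, it means among the compounds named here.

Measured so far in an ADME assay on CCRF-CEM cells (Homo sapiens) for antiproliferative activity, with a stated time of 48 h; a lower number here means a stronger inhibitor, a higher number a weaker inhibitor:
Compound 1 `C=C(Br)C(=O)Nc1ccc(C(=O)/C=C/c2ccccc2)cc1` gives 1500 nM.
Compound 2 `C=C(Br)C(=O)Nc1ccc(C(=O)/C=C/c2ccc(N(C)C)cc2)cc1` gives 1500 nM.
Compound 3 `Nc1ccc(C(=O)/C=C/c2ccccc2)cc1` gives 8500 nM.

Compound 1 and compound 2 differ by dimethylamino in place of hydrogen on an aromatic carbon; the result is no change at the digits printed from compound 1 to compound 2 (within the scatter). Compound 3 differs from compound 1 by hydrogen in place of (1-bromoethenyl)carbonyl on a nitrogen on an aromatic ring; here the result is a 5.7-fold higher number from compound 1 to compound 3 (0.75 log units; beyond the scatter), which leaves compound 3 with the highest number of the three measured compounds.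

Compound 4 `CN(C)c1ccc(/C=C/C(=O)c2ccc(N)cc2)cc1` is not yet measured. It differs from compound 3 by dimethylamino in place of hydrogen on an aromatic carbon. Within the data shown here, this is the same change as the one from compound 1 to compound 2, made on the other core; the two cores differ by hydrogen in place of (1-bromoethenyl)carbonyl on a nitrogen on an aromatic ring.

Among the measured compounds shown here, for compound 4 a step of no change at the digits printed from compound 3 to compound 4 (within the scatter) is expected, resting on the single earlier instance of the change, no change at the digits printed from compound 1 to compound 2 (within the scatter), which stayed within the scatter. For the measured compounds named here, with only one precedent, and on a core whose number sits higher, the expectation is held loosely. Compound 4 is estimated at 8500 nM, with a range of 4000 nM to 18000 nM.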

Compound 4, half-maximal inhibitory concentration: 20000 nM
For compound 4 the middle estimate is 2.4-fold (0.37 log units) below the measured one; the measured number lies above the stated range.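

In this assay, dimethylamino in place of hydrogen on the free-amine core gives a 2.4-fold higher number from compound 3 to compound 4 (0.37 log units; beyond the scatter), and the gap between this step and the one on the acylated core does not separate them: the same change on two cores in this assay, no change at the digits printed (within the scatter) from compound 1 to compound 2 and a 2.4-fold higher number (0.37 log units; beyond the scatter) from compound 3 to compound 4, 2.4-fold (0.37 log units) apart, within the scatter of two such steps. Loss of the (1-bromoethenyl)carbonyl group from the nitrogen in the dimethylamino pair gives a 13-fold higher number from compound 2 to compound 4 (1.12 log units; beyond the scatter), which also cannot be told apart from the same loss in the unsubstituted pair: the same change on two cores in this assay, a 5.7-fold higher number (0.75 log units; beyond the scatter) from compound 1 to compound 3 and a 13-fold higher number (1.12 log units; beyond the scatter) from compound 2 to compound 4, 2.4-fold (0.37 log units) apart, within the scatter of two such steps. Both changes therefore carry from one core to the other as far as these four compounds can show, but with only two instances of each, this does not show that the steps are equal, nor does it establish a dependence on the core.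

On these data alone, it remains open whether a methoxy group or a piperidine ring on the same aromatic carbon would behave as dimethylamino does here. As far as these compounds go, it is also open whether the carrying of steps would hold for an acryloyl or chloroacetyl group on the nitrogen in place of (1-bromoethenyl)carbonyl.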